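From Chloro to Trifluoromethoxy on the Aryl Ether of Compound 1

The source may hold more compounds than are shown below. What is called first, only, known or untested is meant among the compounds shown, and "the series" means these compounds.

Compound 1 `Cc1nnsc1CO/N=C/c1c(C)nn(C)c1Oc1ccccc1Cl` is one of three close relatives tested in a functional assay on PANC-1 cells (Homo sapiens) for inhibition, read by MTT assay, with a stated time of 48 h; a lower number here means a stronger inhibitor, a higher number a weaker inhibitor. In this assay compound 1 gives only a limit, > 50000 nM. Compound 2 `Cc1nnsc1CO/N=C/c1c(C)nn(C)c1Oc1ccc(Br)cc1` gives 12800 nM in this assay. Compound 3 `Cc1ccc(Oc2c(/C=N/OCc3snnc3C)c(C)nn2C)cc1` also gives only a limit in this assay, > 50000 nM. The picture is dominated by the limit of > 50000 nM in this assay, at which 2 of the 3 values shown sit. Among the measured steps, an at least 3.9-fold lower number from compound 1 to compound 2 (0.59 log units; beyond the scatter) is the only one that turns a limit into a number, whereas a step that the two limits leave unreadable from compound 1 to compound 3 cannot be read. Compound 4 `Cc1nnsc1CO/N=C/c1c(C)nn(C)c1Oc1ccccc1OC(F)(F)F` differs from compound 1 by trifluoromethoxy in place of chloro on an aromatic carbon. Among the compounds with values here, no measured step changes this position alone, so the expected step of a number no higher from compound 1 to compound 4 (the limit leaves the size open) is uncertain and may well leave compound 4 at the limit. Compound 4 is estimated at 50000 nM in this assay, with a range from 15000 nM to 200000 nM.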

Compound 4, half-maximal inhibitory concentration: > 50000 nM
Compound 4: no number, only a limit; the forecaster's own chance of this, stated with the estimate: 60%; the middle value lies on the limit itself.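

In this assay compound 4 gives > 50000 nM, a limit and not a number. Compound 1 also gives only a limit, so the step between compound 1 and compound 4 cannot be read: the limit of > 50000 nM in this assay, at which 3 of the 4 values shown sit.

The compounds shown leave open whether trifluoromethoxy and chloro differ in effect at this place.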